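The compounds below may be only part of what the source reports. "The series", "measured", "known", "first", "only" and "open" are said of these compounds alone.

Measured so far:
Compound 1 `N=C(N)N/N=C(/C=C/c1cccc([N+](=O)[O-])c1)c1ccccc1` gives 6500 nM
Compound 2 `N=C(N)N/N=C(/C=C/c1cccc(F)c1)c1ccccc1` gives 16000 nM

Both numbers come from a functional assay on MCF7 cells (Homo sapiens) for antiproliferative activity, read by MTT assay, with a stated time of 48 h (a lower number here means a stronger inhibitor, a higher number a weaker inhibitor), and compound 2 stands highest of the pair at 16000 nM which makes it the weaker inhibitor of the two. Compound 3 `COc1cccc(/C=C/C(=N/NC(=N)N)c2ccccc2)c1` has not been measured yet. It differs from compound 2 as follows: methoxy in place of fluoro on an aromatic carbon that is, methoxy in place of fluoro on an aromatic carbon, meta to a large group.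

For the measured compounds named here, only one measured step bears on this change: a 2.5-fold higher number from compound 1 to compound 2 (0.39 log units; beyond the scatter) for fluoro in place of nitro, which is modest but beyond the scatter. Going by the values given here, that single step shows that an exchange on this aromatic carbon can move the number, yet no measured compound carries methoxy. In this assay a step no larger than that one is therefore expected, and probably none beyond the scatter. The expected change is a 1.2-fold lower number from compound 2 to compound 3 (0.09 log units; within the scatter) as a rough estimate. For compound 3 the estimated value is 13000 nM with an expected range from 5000 nM to 32000 nM in a repeat measurement.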

Compound 3, half-maximal inhibitory concentration: 13000 nM
The estimate for compound 3 equals the measured number at the digits printed; measured number inside the range.
By their numbers in this assay, from the lowest: compounds 1, 3 and 2 (each within the scatter of the next, the first and the last beyond it).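

In this assay, methoxy in place of fluoro on an aromatic carbon, meta to a large group, gives a 1.2-fold lower number from compound 2 to compound 3 (0.09 log units; within the scatter), so the extra heavy atom and the hydrogen-bond acceptor that enter with methoxy leave the number within the scatter of the fluoro compound. Methoxy in place of nitro at the same carbon gives a 2.0-fold higher number from compound 1 to compound 3 (0.30 log units; within the scatter), which also lies within the scatter, even though the earlier exchange between the two outer groups gives a 2.5-fold higher number from compound 1 to compound 2 (0.39 log units; beyond the scatter) and lies beyond it. Compound 3 therefore cannot be placed with either compound 1 or compound 2, and nothing available explains why these three groups give such close numbers.

The compounds shown leave open whether an amine or a carboxylic acid on this carbon would move the number further than any step seen so far. They also leave open whether a longer chain such as ethoxy would stay as close to methoxy, and whether methoxy would give a similar number on another carbon of the same ring.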